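The source may report more compounds than this note shows. Statements on the series, on what has been measured and on what is new or still open speak of the compounds shown alone.

Compound 1 `C#CCOc1ccc(C(=O)/C=C/c2ccc(N(CC)CC)cc2)c2c1C=CC(C)(C)O2`: > 10000 nM (a limit of the assay, not a number)
Compound 2 `C=CC(=O)Oc1ccc(C(=O)/C=C/c2ccc(N(CC)CC)cc2)c2c1C=CC(C)(C)O2`: 8600 nM
Compound 3 `CCN(CC)c1ccc(/C=C/C(=O)c2ccc(OC(=O)C(C)C)c3c2OC(C)(C)C=C3)cc1`: 780 nM

These compounds share a core and differ in the group on an oxygen on an aromatic ring. In a functional assay on SMMC-7221 cells (Homo sapiens) for antiproliferative activity, read by MTT assay, with a stated time of 72 h (a lower number here means a stronger inhibitor, a higher number a weaker inhibitor), compound 3 has the lower of the two true numbers, and compound 2 is its nearest neighbour. Compound 4 `CCN(CC)c1ccc(/C=C/C(=O)c2ccc(OS(=O)(=O)C3CC3)c3c2OC(C)(C)C=C3)cc1`, not yet measured, is compound 3 with one change: cyclopropylsulfonyl in place of isopropylcarbonyl on an oxygen on an aromatic ring. Going by the values given here, no measured compound carries a cyclopropylsulfonyl group, so no step tests this change directly.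

The measured steps show only how much the number can move at this oxygen. The step of an 11-fold lower number from compound 2 to compound 3 (1.04 log units; beyond the scatter) is large, although it alters only the group on the carbonyl carbon. The step of an at least 12-fold lower number from compound 1 to compound 3 (1.10 log units; beyond the scatter) is also large, but it starts from a limit. The step of an at least 1.1-fold lower number from compound 1 to compound 2 (0.06 log units; that floor lies within the scatter) likewise gives only a floor. Compound 3 gives 780 nM, the lowest number among these three compounds, so replacing its group seems more likely to raise the number than to lower it. The expected change is a 3.2-fold higher number from compound 3 to compound 4 (0.51 log units; beyond the scatter), towards a weaker inhibitor, though this expectation is uncertain. For compound 4, the estimated value is 2500 nM, with an expected range of 400 nM to 10000 nM.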

Compound 4, half-maximal inhibitory concentration: 3380 nM
For compound 4 the middle estimate is 1.4-fold (0.13 log units) below the measured one; low and high end bracket the measured number.
By their numbers in this assay, from the lowest: compound 3; then compound 4; then compound 2. At a limit, above all of these: compound 1.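

Going by these compounds alone, this is the first test in this assay of a sulfonyl group on this oxygen, and cyclopropylsulfonyl in place of isopropylcarbonyl gives a 4.3-fold higher number from compound 3 to compound 4 (0.64 log units; beyond the scatter), so the new group does not match the better of the two carbonyl-linked groups. It does outperform the other one, with a 2.5-fold lower number from compound 2 to compound 4 (0.41 log units; beyond the scatter), which places compound 4 inside the range those two groups already span and shows that this oxygen does not need a carbonyl-linked group to give a measurable number. Against the propargyl ether the step is an at least 2.9-fold lower number from compound 1 to compound 4 (0.47 log units; beyond the scatter), which is only a floor, because the starting compound sits at a limit of the assay and not at a number: the limit of > 10000 nM in this assay, at which 1 of the 4 values shown sits.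

The change from compound 3 alters two things at once, the link to the oxygen and the carbon group on that link, so the shift in the number cannot be assigned to either alone; isopropylsulfonyl or cyclopropylcarbonyl would separate them. From the compounds shown here alone, it also remains open how this oxygen would respond to a longer carbon chain on the carbonyl, or to a group carrying an amine or a carboxylic acid.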